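This account rests on a few compounds, and the source may have more. Where it says the series, first, only, none or still open, it means among the compounds named here.

Measured compounds in a functional assay on HCT-116 cells (Homo sapiens), read by MTT assay, with a stated time of 72 h; on this read-out higher numbers stand for weaker inhibition and lower numbers for stronger inhibition:
compound 1 `COc1nc(N)nc2c1c(-c1ccccc1)cn2[C@@H]1O[C@H](CO)[C@@H](O)[C@H]1O`: > 20000 nM
compound 2 `COc1nc(N)nc2c1c(-c1ccsc1)cn2[C@@H]1O[C@H](CO)[C@@H](O)[C@H]1O`: > 20000 nM
compound 3 `COc1ncnc2c1c(-c1cccs1)cn2[C@@H]1O[C@H](CO)[C@@H](O)[C@H]1O`: 440 nM

Compound 3 stands alone among these as the only one with a measured number; in this assay compound 3 gives 440 nM. Compound 1 in this assay reaches only the limit > 20000 nM, which is not a number. Compound 2 likewise gives in this assay only the limit > 20000 nM. Among the measured compounds shown here, the one measured step, a step that the two limits leave unreadable from compound 1 to compound 2, is therefore of unreadable size, both ends sitting at the limit of > 20000 nM in this assay, at which 2 of the 3 values shown sit.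

Compound 4 `COc1nc(N)nc2c1c(-c1cccs1)cn2[C@@H]1O[C@H](CO)[C@@H](O)[C@H]1O` differs from compound 3 by amino in place of hydrogen on an aromatic carbon. For the measured compounds named here, no measured step covers this change directly. What the values show is that the two compounds carrying an amino group on the core, compound 1 and compound 2, both sit at the limit, while compound 3, which lacks it, gives a measurable number; the aromatic substituent differs as well, so this is not a clean comparison.

On that basis the amino group is expected to weaken inhibition, with a 27-fold higher number from compound 3 to compound 4 (1.44 log units; beyond the scatter) as the estimated step, and compound 4 is expected to give about 12000 nM in this assay, within 2000 nM to 60000 nM, with a real chance that only a limit is reported.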

Compound 4, half-maximal inhibitory concentration: > 20000 nM
Compound 4 gave a limit, no number; the forecaster's own chance of this, stated with the estimate: 55%; middle value at least 1.6-fold (0.22 log units) away from the limit.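

In this assay, among the compounds shown here, this result gives the first reading of the position between the two ring nitrogen atoms with the thiophen-2-yl group held constant: amino in place of hydrogen on this aromatic carbon gives an at least 45-fold higher number from compound 3 to compound 4 (1.65 log units; beyond the scatter). The earlier compounds shown here could not show this, as compound 1 and compound 2 both carry the amino group and neither had a partner lacking it, so the change itself is large at this position, at least for this aromatic substituent. The steps from compound 1 and from compound 2 to compound 4 cannot be read, since all three compounds end at a limit, which is not a number, and so the three aromatic groups cannot be ranked in the presence of the amino group: the limit of > 20000 nM in this assay, at which 3 of the 4 values shown sit.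

Going by these compounds, whether a methyl group or a methylamino group on the same carbon would behave like hydrogen or like amino remains open. Also open, on these data alone, is whether phenyl and thiophen-3-yl, without the amino group, would give a measurable number as compound 3 does with thiophen-2-yl.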